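The source may hold more compounds than are shown below. What is called first, only, known or untested is meant among the compounds shown, and "the series" means these compounds.

Compound 1 `C=C1C(=O)O[C@@H]2CC(C)=C([C@@H](C)CCCOC(C)=O)[C@@H](OC(=O)CCl)[C@H]12` sits at the top of the three measured numbers: in a functional assay on SGC-7901 cells (Homo sapiens) for cytotoxicity, read by sulforhodamine B assay, with a stated time of 72 h (a higher number here means a weaker inhibitor, a lower number a stronger inhibitor), compound 1 gives 26500 nM. Compound 2 `C=C1C(=O)O[C@@H]2CC(C)=C([C@@H](C)CCCOC(C)=O)[C@@H](OC(=O)CN3CCCC3)[C@H]12` gives 18400 nM and compound 3 `C=C1C(=O)O[C@@H]2CC(C)=C([C@@H](C)CCCOC(C)=O)[C@@H](OC(=O)CN3CCCCC3)[C@H]12` gives 11500 nM. The new analogue, compound 4 `C=C1C(=O)O[C@@H]2CC(C)=C([C@@H](C)CCCOC(C)=O)[C@@H](OC(=O)COc3ccc4c(CC)noc4c3)[C@H]12`, differs from compound 1 by a group of 12 heavy atoms (9 carbon, 1 nitrogen, 2 oxygen; one five-membered aromatic ring with 2 hetero atoms, one six-membered aromatic ring of carbon only) in place of one chlorine atom, on a saturated chain carbon bound to a carbonyl carbon. Within the data shown here, two measured steps bear on this, since both swap the same chlorine at the same place: a 1.4-fold lower number from compound 1 to compound 2 (0.16 log units; within the scatter), and a 2.3-fold lower number from compound 1 to compound 3 (0.36 log units; beyond the scatter). Both run in the same direction, yet the entering group of compound 4 resembles neither ring amine, so the guidance is loose. For compound 4 the expected step is a 1.8-fold lower number from compound 1 to compound 4 (0.25 log units; within the scatter), a modest lowering at most. Compound 4 is therefore estimated at 15000 nM, with a range from 5000 nM to 45000 nM.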

Compound 4, half-maximal inhibitory concentration: 21200 nM
Compound 4: middle estimate off by 1.4-fold (0.15 log units), on the low side; the range from low to high includes it.
By their numbers in this assay, from the lowest: compounds 3, 2, 4 and 1 (each within the scatter of the next, the first and the last beyond it).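

At this position, on a saturated chain carbon bound to a carbonyl carbon, the much larger group with its two aromatic rings is accommodated with little effect on the number: the result is a 1.3-fold lower number from compound 1 to compound 4 (0.10 log units; within the scatter). Compound 4 also cannot be separated from either ring amine, with a 1.8-fold higher number from compound 3 to compound 4 (0.27 log units; within the scatter) and a 1.2-fold higher number from compound 2 to compound 4 (0.06 log units; within the scatter). Size and ring type of the entering group therefore show no clear effect across these compounds.

From the compounds shown here alone, whether a carboxylic acid or an open-chain diethylamino group here would move the number beyond the scatter stays open. Nothing available explains these results.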